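Phenoxy for acetyl on a shared aryl amide core

The compounds below may be only part of what the source reports. "The series", "measured", "known", "first", "only" and "open" are said of these compounds alone.

Compound 1, `CC(C)N(Cc1cccc(OCCCCCC(=O)O)c1)C(=O)c1ccc(-c2cccc3ccccc23)cc1`, in an ADME assay on Raji cells (Homo sapiens) for cytotoxicity, read by CellTiter-Glo and resazurin assay, with a stated time of 72 h (a lower number here means that less compound is needed, a higher number that more compound is needed for the effect), gives > 26000 nM, a limit of the assay. Compound 2, `CC(=O)c1cccc(-c2ccc(C(=O)N(Cc3cccc(OCCCCCC(=O)O)c3)C(C)C)cc2)c1`, in this assay gives > 26000 nM, again a limit. Compound 3, `CC(C)N(Cc1cccc(OCCCCCC(=O)O)c1)C(=O)c1ccc(-c2ccoc2)cc1`, in this assay gives > 26000 nM, also a limit.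

Compound 2 therefore stands nowhere in particular among the numbers shown: its value is a limit, and the two other values it could be compared with are limits as well. The change from compound 1 to compound 2 is a step that the two limits leave unreadable from compound 1 to compound 2, and from compound 2 to compound 3 it is a step that the two limits leave unreadable from compound 2 to compound 3; neither can be read as a rise or a fall.

Compound 4, `CC(C)N(Cc1cccc(OCCCCCC(=O)O)c1)C(=O)c1ccc(-c2cccc(Oc3ccccc3)c2)cc1`, differs from compound 2 in one place: phenoxy in place of acetyl on an aromatic carbon. Among the compounds with values here, the steps that bear on this change, from compound 1 to compound 2 and from compound 2 to compound 3, were both left unreadable, because all three values sit at the limit of > 26000 nM in this assay, at which 3 of the 3 values shown sit. No direction and no size can be drawn from them for this assay. Compound 4 is therefore expected most probably to sit at the same limit, and its estimated step is a step that the limit leaves unreadable from compound 2 to compound 4. The estimated value for compound 4 is 40000 nM, between 12000 nM and 130000 nM.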

Compound 4, half-maximal effective concentration: > 18700 nM
Compound 4 was reported as a limit; the forecaster's own chance of this, stated with the estimate: 75%; the middle value is on the limit's open side.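

In this assay compound 4 gives > 18700 nM, a limit of the assay. Compound 2 also stands at a limit, so no step can be read between compound 2 and compound 4. The compounds shown leave open where any half-maximal effective concentration lies, and whether phenoxy in place of acetyl changes it at all.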